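The source may report more compounds than this note shows. Statements on the series, on what has been measured and on what is new or still open speak of the compounds shown alone.

Compound 1 `Cc1ccccc1COc1n[nH]c(=S)n1/N=C/c1c[nH]nc1-c1ccc(Cl)cc1` is the simplest member of this small set. In a functional assay on HepG2 cells (Homo sapiens) for cytotoxicity, read by MTT assay, with a stated time of 24 h (on this read-out higher numbers stand for weaker inhibition and lower numbers for stronger inhibition), compound 1 gives 44 ug/mL. Two larger relatives carry an extra group on the shared core: in this assay compound 3 `Cc1ccc(COc2nn(CN(c3ccccc3)c3ccccc3)c(=S)n2/N=C/c2c[nH]nc2-c2ccc(Cl)cc2)cc1` gives 97 ug/mL, and compound 2 `Cc1ccc(COc2nn(CN(c3ccccc3)c3ccccc3)c(=S)n2/N=C/c2c[nH]nc2-c2ccc(F)cc2)cc1` gives 90 ug/mL. Compound 3 and compound 2 differ in a single place, (fluoro in place of chloro on an aromatic carbon), and this change produced a 1.1-fold lower number from compound 3 to compound 2 (0.03 log units; within the scatter). How the core of compound 1 differs from the core of compound 3 is not broken down here; the two values simply show compound 1 with the lower number of the pair.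

Compound 4 `Cc1ccccc1COc1n[nH]c(=S)n1/N=C/c1c[nH]nc1-c1ccc(F)cc1` has not yet been measured. It differs from compound 1 by fluoro in place of chloro on an aromatic carbon, and since the surroundings of that place are described in exactly the same words for both pairs, this is the same change that was already seen between compound 3 and compound 2. Because that earlier change produced a 1.1-fold lower number from compound 3 to compound 2 (0.03 log units; within the scatter), the step from compound 1 to compound 4 is expected to be a 1.1-fold lower number from compound 1 to compound 4 (0.04 log units; within the scatter). Compound 4 is therefore estimated at 40 ug/mL, with a likely range from 20 ug/mL to 80 ug/mL.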

Compound 4, half-maximal inhibitory concentration: 48 ug/mL
Compound 4: the middle estimate sits 1.2-fold (0.08 log units) below what was measured; measured number inside the range.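

In this assay, the new step, fluoro in place of chloro on an aromatic carbon, gives a 1.1-fold higher number from compound 1 to compound 4 (0.04 log units; within the scatter). Set beside the earlier step, the change behaves alike on the two cores, with neither step large enough to separate from ordinary measurement noise: the same change on two cores in this assay, a 1.1-fold lower number (0.03 log units; within the scatter) from compound 3 to compound 2 and a 1.1-fold higher number (0.04 log units; within the scatter) from compound 1 to compound 4, 1.2-fold (0.07 log units) apart, within the scatter of two such steps. This supports carrying the swap between these two cores in this assay, with little movement in the number expected, but it rests on two pairs only, and it does not show that the same would hold on another core or for a different replacement, nor does it give the small steps any real direction.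

The compounds shown leave open what a group other than these two would do at this place, such as an amine, a methoxy group or a carboxylic acid. As far as these compounds go, what the extra group on compound 2 and compound 3 does on its own also stays open, as compound 1 and compound 3 differ in more than one place.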